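This account rests on a few compounds, and the source may have more. Where it says the series, first, only, none or still open, it means among the compounds named here.

Measured compounds:
Compound 1 `Cc1cccn2c(C(=O)c3sc(N)nc3-c3ccccc3)cnc12` gives 20% in a functional assay on the whole organism (strain Sprague-Dawley) for inhibition, with Rattus norvegicus as the target, read by paw edema, with stated times of 1 h and 3 h, at a dose of 50 mg/kg by the oral route; a lower number here means less inhibition, a higher number more inhibition at the dose given (going by the name of the read-out).
Compound 2 `Nc1ncc(C(=O)c2cnc3ccccn23)s1` gives 33% in this assay.

Compound 2 stands highest of the two numbers shown; compound 1 lies lower, a gap beyond the scatter. Compound 3 `Cc1cccn2c(C(=O)c3cnc(N)s3)cnc12` is not yet measured. It differs from compound 2 by methyl in place of hydrogen on an aromatic carbon. Among the compounds with values here, no measured pair shows this change alone, so the size of its step in this assay is unknown; a step within the scatter, in either direction, is expected. Compound 3 is therefore estimated at 30%, between 10% and 50%, an expected step of a number 3 percentage points lower from compound 2 to compound 3 (within the scatter).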

Compound 3, a percentage reported as inhibition, in the whole organism at one dose (the size of the read-out at that dose, not a potency): 31%
Beside the measured number, compound 3's estimate is 1 percentage points below it; the range from low to high includes it.
By their numbers in this assay, from the lowest: compound 1; then compounds 3 and 2 (each within the scatter of the next).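

On this carbon, two atoms from the ring nitrogen, methyl in place of hydrogen stays within the scatter in this assay (a number 2 percentage points lower from compound 2 to compound 3 (within the scatter)). Hydrogen in place of phenyl on an aromatic carbon, now seen alone, goes beyond the scatter, though modestly (a number 11 percentage points higher from compound 1 to compound 3 (beyond the scatter)). Nothing given here accounts for either step.

The compounds shown leave open whether methyl behaves the same with phenyl present. They also leave open whether a methoxy or ethyl group on this carbon would move the inhibition.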